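Amine side-chain swap on the shared core, oral exposure

This account rests on a few compounds, and the source may have more. Where it says the series, first, only, none or still open, it means among the compounds named here.

For the measured compounds named here, in an ADME assay on the whole organism (strain FVB) for pharmacokinetics, with Mus musculus as the target, read by LC-MS, at a dose of 30 mg/kg by the oral route (a higher number here means more compound in the circulation at the dose given, a lower number less compound in the circulation), compound 1 `CC(C)(O)CNCCCOc1ccc([C@H]2CC[C@]3(CC2)OOC2(O3)C3CC4CC(C3)CC2C4)cc1` gives 11100 ng.h/mL and stands highest of the two numbers measured so far. Going by the values given here, compound 2 `c1cc([C@H]2CC[C@]3(CC2)OOC2(O3)C3CC4CC(C3)CC2C4)ccc1OCC1CCNCC1` gives 4040 ng.h/mL in this assay, and the step of a 2.7-fold lower number from compound 1 to compound 2 (0.44 log units; beyond the scatter) is the only measured change, one that also touches the amine-bearing side chain. Compound 3 `O[C@H]1CC[C@H](NCCCOc2ccc([C@H]3CC[C@]4(CC3)OOC3(O4)C4CC5CC(C4)CC3C5)cc2)CC1` differs from compound 1 as follows: 4-hydroxycyclohexyl in place of 2-hydroxy-2-methylpropyl on an amine nitrogen. Among the compounds with values here, the one step bearing on this region was modest, so a similar or smaller shift is expected here. Compound 3 is estimated at 8000 ng.h/mL in this assay, with a range from 3000 ng.h/mL to 20000 ng.h/mL, corresponding to an expected step of a 1.4-fold lower number from compound 1 to compound 3 (0.14 log units; within the scatter).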

Compound 3, area under the concentration-time curve: 6570 ng.h/mL
Compound 3: middle estimate off by 1.2-fold (0.09 log units), on the high side; low and high end bracket the measured number.
By their numbers in this assay, from the lowest: compounds 2, 3 and 1 (each within the scatter of the next, the first and the last beyond it).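

In this assay the change to 4-hydroxycyclohexyl on the amine nitrogen reads a 1.7-fold lower number from compound 1 to compound 3 (0.23 log units; within the scatter) and so cannot be told apart from 2-hydroxy-2-methylpropyl at this position. Against the piperidin-4-yl side chain the step reads a 1.6-fold higher number from compound 2 to compound 3 (0.21 log units; within the scatter) while compound 1 and compound 2 stand apart beyond the scatter, so compound 3 sits with neither one clearly.

On these data alone, how a methoxy in place of the hydroxyl, or a carboxylic acid on the amine nitrogen, would read in this assay stays open. Nothing on hand explains any of these steps.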